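This account rests on a few compounds, and the source may have more. Where it says the series, first, only, none or still open, it means among the compounds named here.

Measured so far in a functional assay on MGC-803 cells (Homo sapiens) for inhibition, read by CCK-8 assay, with a stated time of 48 h; a higher number here means a weaker inhibitor, a lower number a stronger inhibitor:
compound 1 `COc1ccc(CN(C(=O)CSC(=S)N2CCN(C)CC2)c2cc(OC)c(OC)c(OC)c2)cc1` gives 1280 nM
compound 2 `COc1ccc(CN(C(=O)CSC(=S)N2CCN(C(C)=O)CC2)c2cc(OC)c(OC)c(OC)c2)cc1` gives 480 nM
compound 3 `COc1ccc(CN(C(=O)CSC(=S)N2CCN(C(=O)OC(C)(C)C)CC2)c2cc(OC)c(OC)c(OC)c2)cc1` gives 310 nM

Compound 3 holds the lowest number of the three. Its nearest neighbour is compound 2, at a 1.5-fold lower number from compound 2 to compound 3 (0.19 log units; within the scatter); the furthest is compound 1, at a 4.1-fold lower number from compound 1 to compound 3 (0.62 log units; beyond the scatter). Compound 4 `COc1ccc(CN(C(=O)CSC(=S)N2CCN(C(=O)OC(C)(C)C)CC2)c2ccccc2)cc1` differs from compound 3 in one place: phenyl in place of 3,4,5-trimethoxyphenyl on an amide-type nitrogen. Within the data shown here, every measured step, a 2.7-fold lower number from compound 1 to compound 2 (0.43 log units; beyond the scatter), a 4.1-fold lower number from compound 1 to compound 3 (0.62 log units; beyond the scatter) and a 1.5-fold lower number from compound 2 to compound 3 (0.19 log units; within the scatter), alters the amine nitrogen in a ring; no measured step touches the amide-type nitrogen, so nothing here calibrates this change. The expected step is therefore stated with a wide range: a 6.5-fold higher number from compound 3 to compound 4 (0.81 log units; beyond the scatter). Compound 4 is estimated at 2000 nM, between 400 nM and 10000 nM, in this assay.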

Compound 4, half-maximal inhibitory concentration: > 20000 nM
Compound 4 ended at the assay's limit (the forecaster's own chance of this, stated with the estimate: 15%); middle value at least 10-fold (1.00 log units) away from the limit.
By their numbers in this assay, from the lowest: compounds 3 and 2 (each within the scatter of the next); then compound 1. At a limit, above all of these: compound 4.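

Phenyl in place of 3,4,5-trimethoxyphenyl on an amide-type nitrogen gives an at least 64-fold higher number from compound 3 to compound 4 (1.80 log units; beyond the scatter), a larger step than any printed for changes on the amine nitrogen in a ring. In this assay compound 4 gives > 20000 nM, which is a limit and not a number: the limit of > 20000 nM in this assay, at which 1 of the 4 values shown sits.

In this single pair, inhibition depends strongly on the group at the amide-type nitrogen. On these data alone, whether all three methoxy groups are needed stays open, and a methoxyphenyl or dimethoxyphenyl group at that nitrogen would bear on this.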